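The source may report more compounds than this note shows. Statements on the series, on what has been measured and on what is new or still open speak of the compounds shown alone.

The measured compounds:
compound 1, `N#CCn1c(=O)n(-c2ccc(C#N)c(C(F)(F)F)c2)c2ccccc21`: 18900 nM
compound 2, `Cc1ccc(-n2c(=O)n(-c3ccc(C#N)c(C(F)(F)F)c3)c3ccccc32)cc1`: 790 nM
compound 3, `N#Cc1ccc(-n2c(=O)n(Cc3ccccc3)c3cccnc32)cc1C(F)(F)F`: < 500 nM

In a physicochemical assay for solubility (a higher number here means a more soluble compound, a lower number a less soluble compound), compound 1 gives the highest of the two numbers that were read as numbers. Its nearest neighbour, compound 2, sits far lower, and the step of a 24-fold lower number from compound 1 to compound 2 (1.38 log units; beyond the scatter) exchanges a small chain group on an aromatic nitrogen for an aromatic ring. Compound 3 is reported only as a limit of this assay, (the limit of < 500 nM in this assay, at which 1 of the 3 values shown sits).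

Compound 4, `CNC(=O)c1ccc(Cn2c(=O)n(-c3ccc(C#N)c(C(F)(F)F)c3)c3ccccc32)cc1F`, has not yet been measured. It differs from compound 1 in one place: 3-fluoro-4-(methylcarbamoyl)phenyl in place of cyano on a saturated chain carbon bound to an aromatic nitrogen. Among the measured compounds shown here, the only measured step that bears on this change is the one from compound 1 to compound 2, where an aromatic ring also entered at the same nitrogen and the number fell by a large margin. The group entering in compound 4 is larger still, so a drop of similar size is expected, with wide uncertainty. Compound 4 is therefore estimated at 2500 nM, between 600 nM and 10000 nM, the expected step being a 7.6-fold lower number from compound 1 to compound 4 (0.88 log units; beyond the scatter).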

Compound 4, solubility: 9900 nM
For compound 4 the middle estimate is 4.0-fold (0.60 log units) below the measured one; measured number inside the range.
By their numbers in this assay, from the lowest: compound 2; then compounds 4 and 1 (each within the scatter of the next). At a limit, below all of these: compound 3.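

In this assay, the change on the saturated chain carbon bound to an aromatic nitrogen gives a 1.9-fold lower number from compound 1 to compound 4 (0.28 log units; within the scatter) and so leaves no readable difference. Cyano can therefore give way to 3-fluoro-4-(methylcarbamoyl)phenyl, a far larger group with an aromatic ring, without a shift beyond the scatter. The earlier step, a 24-fold lower number from compound 1 to compound 2 (1.38 log units; beyond the scatter) with the ring on the nitrogen itself, had suggested that an aromatic ring at this site brings a large fall, but compound 4 shows that this does not hold once the saturated chain carbon stays in place.

Nothing measured here explains why these two steps differ in size. From the compounds shown here alone, it also remains open whether the same flat result would hold with an amine or a carboxylic acid in place of the methylcarbamoyl group, or with a plain benzyl group.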